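Reversing the amide and shortening the chain on a shared core

A few compounds are considered here, and "the series" means these few. Any claim that something is new, unique, unknown or untested is made for them only; others in the source may bear on it.

Measured compounds:
Compound 1, `CN(C)C(=O)c1cc2cnc(Nc3ccc(S(=O)(=O)NCCCN=C=S)cc3)nc2n1C1CCCC1`: 72.8%
Compound 2, `CN(C)C(=O)c1cc2cnc(Nc3ccc(C(=O)NCCCCCCN=C=S)cc3)nc2n1C1CCCC1`: 85%

In a functional assay on NCI-H1299 cells (Homo sapiens) for inhibition, read by CCK-8 assay, with a stated time of 72 h, tested at 10 uM (on this read-out higher numbers stand for a stronger effect at the one concentration tested and lower numbers for a weaker effect), compound 2 gives the higher of the two numbers shown, and compound 1 gives 72.8%. Going by the values given here, the one measured step, a number 12.2 percentage points higher from compound 1 to compound 2 (beyond the scatter), changed the group on the same aromatic carbon that is altered again here.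

Compound 3, `CN(C)C(=O)c1cc2cnc(Nc3ccc(NC(=O)CCCN=C=S)cc3)nc2n1C1CCCC1`, differs from compound 2 in that (a group of 9 heavy atoms (5 carbon, 2 nitrogen, 1 oxygen, 1 sulfur; no ring) in place of a group of 12 heavy atoms (8 carbon, 2 nitrogen, 1 oxygen, 1 sulfur; no ring), on an aromatic carbon). Among the compounds with values here, no measured step shows this particular change, so the expectation rests only on the fact that the same position tolerated a modest gain in the step from compound 1 to compound 2, with no evidence on a shorter chain or a reversed amide.

Compound 3 is therefore expected to sit near compound 2, with a modest fall judged more likely than a rise, giving a number 10 percentage points lower from compound 2 to compound 3 (within the scatter). The estimated inhibition of compound 3 is 75%, in the range 55% to 90%.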

Compound 3, a percentage reported as inhibition, at one concentration (the size of the read-out at that concentration, not a potency): 78.8%
Estimate against measurement, compound 3: 3.8 percentage points below; measured number inside the range.
By their numbers in this assay, from the lowest: compounds 1, 3 and 2 (each within the scatter of the next, the first and the last beyond it).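

On the aromatic carbon para to a large group, the group of 9 heavy atoms gives in this assay a number 6.2 percentage points lower from compound 2 to compound 3 (within the scatter) and also a number 6 percentage points higher from compound 1 to compound 3 (within the scatter). Going by these compounds alone, compound 3 thus cannot be told apart from either earlier compound, although those two are separated by a number 12.2 percentage points higher from compound 1 to compound 2 (beyond the scatter), so this position accepts a group with three fewer heavy atoms than the one in compound 2 without a difference this read-out can resolve. Nothing available explains this result.

Because the step to compound 3 changes both the chain and the amide together, the compounds shown do not separate the two changes, and a longer chain on the reversed amide would be needed to do so. They also leave open whether the isothiocyanate matters, which an amine or a carboxylic acid at the chain end could test.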